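Compound 3: methyl in place of fluoro

This account rests on a few compounds, and the source may have more. Where it says the series, first, only, none or still open, it means among the compounds named here.

Among the compounds with values here, in an ADME assay on microsomes from liver (Mus musculus) for metabolic stability, read by LC-MS, using NADPH, with a stated time of 10 min, tested at 0.5 uM (on this read-out lower numbers stand for a less stable compound and higher numbers for a more stable compound), compound 1 (`CC(=O)Nc1cc(-c2ccc(OC[C@@](C)(N)CC(C)C)c(F)c2)ccn1`) gives 70% and compound 2 (`CC(=O)Nc1cc(-c2ccc(OC[C@@H](N)CC(C)C)c(F)c2)ccn1`) gives 79% in the only two measurements so far. These values lie within the usual scatter of each other, so compound 2 stands level with compound 1. Compound 3 (`CC(=O)Nc1cc(-c2ccc(OC[C@@H](N)CC(C)C)c(C)c2)ccn1`) differs from compound 2 in one place, with methyl in place of fluoro on an aromatic carbon. Within the data shown here, the one measured step (a number 9 percentage points higher from compound 1 to compound 2 (within the scatter)) concerns a different group, 1-amino-3-methylbutyl in place of 1-amino-1,3-dimethylbutyl, so it bears on this change only loosely. Among the measured compounds shown here, no measurement yet covers fluoro against methyl, so the data give no direction, and no shift beyond the scatter is expected in this assay for this change. The expected step is small (a number 5 percentage points lower from compound 2 to compound 3 (within the scatter)) and remains uncertain. For compound 3 the estimated value is 74% with a range from 54% to 90% on repeated measurement.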

Compound 3, percent of the compound remaining: 64%
Estimate against measurement, compound 3: 10 percentage points above; the range from low to high includes it.
By their numbers in this assay, from the lowest: compounds 3, 1 and 2 (each within the scatter of the next, the first and the last beyond it).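

Among the compounds shown, only this pair differs at the aromatic carbon ortho to the (2-amino-4-methylpentyl)oxy group, and in this assay the change gives a step beyond the scatter: a number 15 percentage points lower from compound 2 to compound 3 (beyond the scatter). The read-out therefore responds to what sits on this carbon, even though fluoro and methyl each count as one heavy atom with no hydrogen-bond donors or acceptors, whereas the earlier change on the chain stayed within the scatter: a number 9 percentage points higher from compound 1 to compound 2 (within the scatter). Nothing available here accounts for this lower number.

With only fluoro and methyl shown at this carbon, it remains open whether a chlorine atom, a methoxy group or a plain hydrogen there would stay nearer compound 2 or fall further. As far as these compounds go, it also remains open whether the same swap would give a similar step with the 1-amino-1,3-dimethylbutyl chain of compound 1.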